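Cytotoxicity notes: removing one chloro from compound 2

A few compounds are considered here, and "the series" means these few. Any claim that something is new, unique, unknown or untested is made for them only; others in the source may bear on it.

Compound 1 `COc1ccc(Sc2cn(-c3ccc4c(c3)B(O)OC4)c3ccccc23)cc1`: in an ADME assay on L929 cells (Mus musculus) for cytotoxicity, read by resazurin assay, with a stated time of 72 h (on this read-out lower numbers stand for stronger inhibition and higher numbers for weaker inhibition), compound 1 gives > 10 ug/mL, a limit of the assay.
Compound 2 `OB1OCc2ccc(-n3cc(Sc4ccc(Cl)c(Cl)c4)c4ccccc43)cc21`: in this assay compound 2 gives > 10 ug/mL, also a limit of the assay.

Compound 2 thus sits at the limit of > 10 ug/mL in this assay, at which 2 of the 2 values shown sit. Among the measured compounds shown here, the one measured step, a step that the two limits leave unreadable from compound 1 to compound 2, cannot be sized. Compound 3 `OB1OCc2ccc(-n3cc(Sc4cccc(Cl)c4)c4ccccc43)cc21` differs from compound 2 by hydrogen in place of chloro on an aromatic carbon, a smaller structural change than that step. With both measured values at the limit, no direction is readable, and the step that the limit leaves unreadable from compound 2 to compound 3 is expected to stay within the scatter. Compound 3 is therefore estimated at 15 ug/mL, with a range from 8 ug/mL to 40 ug/mL, most likely again reported only as a limit.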

Compound 3, half-maximal inhibitory concentration: > 10 ug/mL
Compound 3: only a limit was reported; the forecaster's own chance of this, stated with the estimate: 80%; the middle value lies beyond the limit too.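

No step can be read among compound 1, compound 2 and compound 3 in this assay, since each value is only a limit of the assay: the limit of > 10 ug/mL in this assay, at which 3 of the 3 values shown sit.

As far as these compounds go, how far the 3,4-dichlorophenyl, 3-chlorophenyl and 4-methoxyphenyl groups on the sulfur separate these compounds in cytotoxicity remains open.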